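This account rests on a few compounds, and the source may have more. Where it says the series, first, only, none or still open, it means among the compounds named here.

Measured in a functional assay on the whole organism (strain Sprague-Dawley) for inhibition, with Rattus norvegicus as the target, with a stated time of 10 min; a higher number here means that more compound is needed for the effect, a lower number that less compound is needed:

- compound 1 `O=C(O)c1cnc(-c2ccccc2F)[nH]c1=O`: 5 mg/kg
- compound 2 `Nc1ccccc1-c1ncc(C(=O)O)c(=O)[nH]1`: 50 mg/kg
- compound 3 `CCOc1ccccc1-c1ncc(C(=O)O)c(=O)[nH]1`: 0.5 mg/kg

Compound 3 has the lowest of these three numbers, and its distance to each of the other two lies beyond the scatter. The next compound, compound 4 `CCCCOc1ccccc1-c1ncc(C(=O)O)c(=O)[nH]1`, carries butoxy instead of ethoxy, and the change is ethyl in place of hydrogen on a saturated chain carbon, two bonds along the chain from an oxygen on an aromatic ring. It puts ethyl in place of hydrogen on a saturated chain carbon, two bonds along the chain from an oxygen on an aromatic ring.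

Within the data shown here, no measured step lengthens this chain. The nearest evidence comes from two steps that introduce ethoxy on an aromatic carbon, a 10-fold lower number from compound 1 to compound 3 (1.00 log units; beyond the scatter) and a 100-fold lower number from compound 2 to compound 3 (2.00 log units; beyond the scatter). A third step, a 10-fold higher number from compound 1 to compound 2 (1.00 log units; beyond the scatter), also shows how far the number in this assay can move when the group on that carbon changes. All of these replace one group with a different kind of group, whereas the step to compound 4 keeps the ethereal oxygen and only extends the chain, so a smaller shift is expected. With compound 3 already at 0.5 mg/kg, a small rise seems somewhat more likely than a further fall, though either direction remains possible. The expected step is a 2.0-fold higher number from compound 3 to compound 4 (0.30 log units; within the scatter). For compound 4 the estimated value is 1 mg/kg, with an expected range from 0.2 mg/kg to 5 mg/kg.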

Compound 4, dose for 50% inhibition: 0.5 mg/kg
Compound 4: the middle estimate sits 2.0-fold (0.30 log units) above what was measured; the measured number falls inside the stated range.
By their numbers in this assay, from the lowest: compounds 3 and 4 (each within the scatter of the next); then compound 1; then compound 2.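

In this assay, extending the ether chain from ethoxy to butoxy leaves the number where it was (no change at the digits printed from compound 3 to compound 4 (within the scatter)), so adding ethyl on this saturated chain carbon produces no shift beyond the scatter. The lower numbers seen earlier with ethoxy on the aromatic carbon are therefore not unique to that group among the compounds shown: butoxy in place of fluoro gives the step (a 10-fold lower number from compound 1 to compound 4 (1.00 log units; beyond the scatter)), and butoxy in place of amino gives the step (a 100-fold lower number from compound 2 to compound 4 (2.00 log units; beyond the scatter)), matching in size the steps to compound 3. No available measurement accounts for the absence of a change between these two ether chains.

With only ethoxy and butoxy shown, the numbers establish no trend with chain length, and it remains open whether a longer chain such as hexyloxy or a branched one such as isopropoxy would keep the number at this level. On these data alone, it also remains open how an ether chain carrying an amine or a carboxylic acid would read in this assay.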